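Sulfonyl versus carbonyl on the ring nitrogen; trifluoromethyl next

A few compounds are considered here, and "the series" means these few. Any claim that something is new, unique, unknown or untested is made for them only; others in the source may bear on it.

Measured in a functional assay on MDA-MB-231 cells (Homo sapiens) for inhibition, read by sulforhodamine B assay, tested at 10 uM; a lower number here means less inhibition, a higher number more inhibition at the concentration tested (going by the name of the read-out):
compound 1 `COC(=O)CC(=O)N1N=C(c2ccc(N3CCN(C)CC3)cc2)CC1c1ccc(N(C)C)cc1` gives -0.4%
compound 2 `Cc1ccc(C(=O)N2N=C(c3ccc(N4CCN(C)CC4)cc3)CC2c2ccc(N(C)C)cc2)cc1` gives -0.7%
compound 3 `Cc1ccc(S(=O)(=O)N2N=C(c3ccc(N4CCN(C)CC4)cc3)CC2c2ccc(N(C)C)cc2)cc1` gives 10.7%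

Compound 3 stands highest of the three in this assay; the step of a number 11.1 percentage points higher from compound 1 to compound 3 (beyond the scatter) and the step of a number 11.4 percentage points higher from compound 2 to compound 3 (beyond the scatter) are both beyond the scatter, whereas a number 0.3 percentage points lower from compound 1 to compound 2 (within the scatter) is within it.

Compound 4 `CN1CCN(c2ccc(C3=NN(S(=O)(=O)c4ccc(C(F)(F)F)cc4)C(c4ccc(N(C)C)cc4)C3)cc2)CC1` keeps the sulfonyl of compound 3 and differs in one place: trifluoromethyl in place of methyl on an aromatic carbon.

For the measured compounds named here, none of the measured steps touches the (4-methylphenyl)sulfonyl group itself; they only swap what sits on the ring nitrogen. Going by the values given here, no measured pair therefore bears on this change, and no step beyond the scatter is expected in this assay. The estimated step of a number 0.7 percentage points lower from compound 3 to compound 4 (within the scatter) is meant as flat. For compound 4 the expected value is 10%, with a range from -2% to 25%.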

Compound 4, a percentage reported as inhibition, at one concentration (the size of the read-out at that concentration, not a potency): 12.1%
Estimate against measurement, compound 4: 2.1 percentage points below; the measured number falls inside the stated range.
By their numbers in this assay, from the lowest: compounds 2 and 1 (each within the scatter of the next); then compounds 3 and 4 (each within the scatter of the next).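

For the compounds shown here, earlier steps changed only what sits on the ring nitrogen; this is the first change on the aromatic ring of the sulfonyl group, para to a large group. In this assay, trifluoromethyl in place of methyl gives a number 1.4 percentage points higher from compound 3 to compound 4 (within the scatter) and so leaves the number level, with the sulfonyl compounds still together. No measurement at hand accounts for this result.

On these data alone, whether an amine or a carboxylic acid on this aromatic carbon would move the number beyond the scatter remains open. So does the effect of a longer chain there.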